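The source may report more compounds than this note shows. Statements on the series, on what has been measured and on what is new or still open speak of the compounds shown alone.

Compound 1, `COc1cccc(/C=C/C(=O)C(=Cc2ccc(O)c(F)c2)C(=O)/C=C/c2cccc(OC)c2OC)c1OC`, and compound 2, `COc1cc(C=C(C(=O)/C=C/c2cccc(OC)c2OC)C(=O)/C=C/c2cccc(OC)c2OC)cc(Br)c1O`, share one core and differ only in one ring. In a functional assay on SW480 cells (Homo sapiens) for antiproliferative activity, read by sulforhodamine B assay, with a stated time of 48 h (a higher number here means a weaker inhibitor, a lower number a stronger inhibitor), compound 1 gives 330 nM, and compound 2 gives 260 nM. The change between them is 3-bromo-4-hydroxy-5-methoxyphenyl in place of 3-fluoro-4-hydroxyphenyl on a double-bonded chain carbon bound to a double-bonded chain carbon, and it made a step of a 1.3-fold lower number from compound 1 to compound 2 (0.10 log units; within the scatter), so the two values show no order that can be trusted.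

Compound 3, `COc1ccc(/C=C/C(=O)C(=Cc2ccc(O)c(F)c2)C(=O)/C=C/c2ccc(OC)cc2OC)c(OC)c1`, is built from the same atoms as compound 1 but joined differently; how the two cores differ is not broken down here. In this assay compound 3 gives 3350 nM, which stands as the highest of the three numbers, beyond the scatter from both compound 1 and compound 2.

Compound 4, `COc1ccc(/C=C/C(=O)C(=Cc2cc(Br)c(O)c(OC)c2)C(=O)/C=C/c2ccc(OC)cc2OC)c(OC)c1`, has not yet been measured. It differs from compound 3 by 3-bromo-4-hydroxy-5-methoxyphenyl in place of 3-fluoro-4-hydroxyphenyl on a double-bonded chain carbon bound to a double-bonded chain carbon, the same change, at the same place, as that from compound 1 to compound 2. Because that earlier step was a 1.3-fold lower number from compound 1 to compound 2 (0.10 log units; within the scatter), the expectation is that the step from compound 3 to compound 4 in this assay will be of similar size, a 1.3-fold lower number from compound 3 to compound 4 (0.11 log units; within the scatter), and will stay within the scatter. On that basis compound 4 is expected to give 2600 nM in this assay, with a likely range from 1200 nM to 5500 nM, since the same change on the core of compound 3 may not carry over exactly and the core of compound 3 itself is tied to a high number.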

Compound 4, half-maximal inhibitory concentration: 1480 nM
Compound 4: middle estimate off by 1.8-fold (0.24 log units), on the high side; the range from low to high includes it.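

In this assay, placing 3-bromo-4-hydroxy-5-methoxyphenyl where 3-fluoro-4-hydroxyphenyl stood gave a 2.3-fold lower number from compound 3 to compound 4 (0.35 log units; beyond the scatter), a modest step, whereas the same change on the core of compound 1 gave a step within the scatter. Even so, the two steps cannot be told apart, and the data give no sign that the core alters what this change does: the same change on two cores in this assay, a 1.3-fold lower number (0.10 log units; within the scatter) from compound 1 to compound 2 and a 2.3-fold lower number (0.35 log units; beyond the scatter) from compound 3 to compound 4, 1.8-fold (0.25 log units) apart, within the scatter of two such steps

This supports carrying the change between these two cores only in a limited sense, as the results are compatible with a step of similar size on both, but it does not show that the size is fixed, that the change has a real effect on the core of compound 1, or that the result would hold on any further core.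

The compounds shown leave open what happens when a different group stands on the double-bonded chain carbon, such as a phenyl ring carrying an amine or a carboxylic acid in place of the bromine. Also open, as far as these compounds go, is how the same change behaves on a third core, for instance one carrying ethoxy groups in place of the methoxy groups.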